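The source may hold more compounds than are shown below. What is called first, only, known or untested is meant among the compounds shown, and "the series" means these compounds.

Compound 3 `Clc1ccc(-c2cc(-c3ccc(Cl)o3)cc(-c3ccsc3)n2)cc1` stands highest of the three compounds tested in an assay on isolated protein for inhibition of DNA topoisomerase 1 (Homo sapiens), tested at 100 uM (on this read-out higher numbers stand for a stronger effect at the one concentration tested and lower numbers for a weaker effect), giving 29.8%. Compound 2 `Clc1ccc(-c2cc(-c3cccnc3)nc(-c3cccs3)c2)o1` lies nearest to it, with 25.8% in this assay, a gap within the scatter, while compound 1 `Clc1ccc(-c2cc(-c3ccsc3)nc(-c3ccccc3Cl)c2)o1` lies furthest, with 0%. The single measured step, a number 29.8 percentage points higher from compound 1 to compound 3 (beyond the scatter), is the only one beyond the scatter among these numbers.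

Compound 4 `Clc1ccc(-c2cc(-c3cccnc3)nc(-c3ccsc3)c2)o1` differs from compound 3 in one place: pyridin-3-yl in place of 4-chlorophenyl on an aromatic carbon. Within the data shown here, no measured step covers this exchange, so the step from compound 1 to compound 3, which swaps one chlorophenyl for another, bears on it only loosely. The same pyridin-3-yl and 5-chlorofuran-2-yl groups as in compound 4 are carried by compound 2, which gives 25.8%, and this suggests the exchange leaves this assay roughly where compound 3 stands. Compound 4 is therefore expected to give about 26%, between 8% and 44%, an estimated step of a number 3.8 percentage points lower from compound 3 to compound 4 (within the scatter), not beyond the scatter.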

Compound 4, a percentage reported as inhibition, at one concentration (the size of the read-out at that concentration, not a potency): 0%
Compound 4: middle estimate off by 26 percentage points, on the high side, outside the stated range (below it).
By their numbers in this assay, from the lowest: compounds 1 and 4 (each within the scatter of the next); then compounds 2 and 3 (each within the scatter of the next).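

With thiophen-3-yl kept in the neighbouring part of the structure, pyridin-3-yl on the carbon next to the ring nitrogen in place of 4-chlorophenyl gives a number 29.8 percentage points lower from compound 3 to compound 4 (beyond the scatter) in this assay, so among these groups the reading at this position follows the 4-chlorophenyl group. The exchange of pyridin-3-yl for 2-chlorophenyl gives no change at the digits printed from compound 1 to compound 4 (within the scatter), so these two groups cannot be told apart here. The pyridin-3-yl group does not fix the number alone, since thiophen-3-yl in place of thiophen-2-yl gives a number 25.8 percentage points lower from compound 2 to compound 4 (beyond the scatter).

Nothing shown explains these differences. Going by these compounds, it remains open whether an unsubstituted phenyl, a 4-aminophenyl or a 4-carboxyphenyl at this position would read like compound 3 or like compound 4.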